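The source may report more compounds than this note shows. Statements on the series, on what has been measured and on what is new or still open speak of the compounds shown alone.

Working notes on the shared core of compound 1 `COc1cccc(/C=C2\CCC/C(=C\c3cccc(Cl)c3Cl)C2=O)c1OC`, compound 2 `COc1cccc(/C=C2\CCC/C(=C\c3ccc(O)c(O)c3)C2=O)c1OC`, compound 3 `COc1ccc(/C=C2\CCC/C(=C\c3ccc(Cl)cc3)C2=O)cc1OC` and compound 4 `COc1ccc(/C=C2\CCC/C(=C\c3ccc(Cl)cc3Cl)C2=O)cc1OC`, read in an ADME assay on NHDF cells (Homo sapiens) for cytotoxicity, read by MTT assay, with a stated time of 72 h; a higher number here means a weaker inhibitor, a lower number a stronger inhibitor.

Compound 1 gives only a limit, > 50000 nM, in this assay. Compound 2 gives 17900 nM, and compound 3 gives 11200 nM. Compound 3 and compound 2 fall within the usual scatter of each other, so no order is drawn between them; compound 3 is simply the lower of the two numbers, with compound 1 standing apart as a limit (the limit of > 50000 nM in this assay, at which 1 of the 3 values shown sits).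

Within the data shown here, the one measured step, an at least 2.7-fold lower number from compound 1 to compound 2 (0.44 log units; beyond the scatter), replaces a dichlorophenyl with a dihydroxyphenyl on the chain carbon and moves the value from the limit to a number.

Compound 4 differs from compound 3 by chloro in place of hydrogen on an aromatic carbon. This is a move toward a dichlorinated aryl, the kind of aryl compound 1 carries, and compound 1 gave only the limit > 50000 nM. That step is the only one in hand and it bears only loosely, since it swaps chlorines for hydroxyls rather than adding a chlorine. The expected step is therefore a 1.4-fold higher number from compound 3 to compound 4 (0.15 log units; within the scatter), leaning toward a higher number but not clearly beyond the scatter. The estimate for compound 4 in this assay is 16000 nM, with a range from 6000 nM to 45000 nM.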

Compound 4, half-maximal inhibitory concentration: > 50000 nM
Compound 4 was reported as a limit; the forecaster's own chance of this, stated with the estimate: 15%; middle value at least 3.1-fold (0.49 log units) away from the limit.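

In this assay, the change from 4-chlorophenyl to 2,4-dichlorophenyl, with chloro in place of hydrogen on an aromatic carbon ortho to a large group and meta to a chloro group, gives an at least 4.4-fold higher number from compound 3 to compound 4 (0.64 log units; beyond the scatter). This shows that a single added chloro at this position is enough to move the number beyond the scatter, which the earlier step could not show, as it exchanged a dichlorophenyl for a dihydroxyphenyl and so changed more than one place on the aryl. Compound 4 is reported only as a limit, so the step is a lower bound whose full size cannot be read, and compound 4 joins compound 1 at that limit: the limit of > 50000 nM in this assay, at which 2 of the 4 values shown sit.

Open, as far as these compounds go, is whether this shift belongs to chloro specifically or would also follow from another group on the same aromatic carbon, such as fluoro, methyl or an amine. Also open, from the compounds shown here alone, is whether the chloro at this position would act the same way without the 4-chloro group already on the ring, or on the aryl of compound 1 and compound 2.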